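From Nitro to Chloro in a Small Cytotoxic Series

The source may report more compounds than this note shows. Statements on the series, on what has been measured and on what is new or still open speak of the compounds shown alone.

In a functional assay on DU-145 cells (Homo sapiens) for cytotoxicity, read by MTT assay, with a stated time of 48 h (a lower number here means a stronger inhibitor, a higher number a weaker inhibitor), compound 1 `CC(C)n1c(/C=C2/C(=O)Nc3ccc(Br)cc32)nc2ccccc21` gives 7500 nM and compound 2 `CC(C)n1c(/C=C2/C(=O)Nc3ccc(F)cc32)nc2ccccc21` gives 24500 nM. Compound 3 `Cn1c(/C=C2/C(=O)Nc3ccc([N+](=O)[O-])cc32)nc2ccccc21` reaches only a limit, > 50000 nM. Compound 4 `Cn1c(/C=C2/C(=O)Nc3ccc(Cl)cc32)nc2ccccc21` replaces the nitro of compound 3 with chloro on an aromatic carbon, para to a fused ring: chloro in place of nitro on an aromatic carbon. Among the compounds with values here, no measured step covers this exchange directly. The closest evidence is a 3.3-fold higher number from compound 1 to compound 2 (0.51 log units; beyond the scatter), a modest change with fluoro in place of bromo, and both of those compounds differ from compound 4 elsewhere too. A move towards a lower number in this assay is expected, of uncertain size. The expected change is an at least 2.7-fold lower number from compound 3 to compound 4 (0.44 log units; beyond the scatter). Compound 4 is estimated at 18000 nM, within an expected range of 6000 nM to 50000 nM.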

Compound 4, half-maximal inhibitory concentration: 38900 nM
Compound 4: the middle estimate sits 2.2-fold (0.33 log units) below what was measured, and the stated range covers the measured number.
By their numbers in this assay, from the lowest: compound 1; then compounds 2 and 4 (each within the scatter of the next). At a limit, above all of these: compound 3.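

Chloro in place of nitro on this aromatic carbon, para to a fused ring, turns a limit into a measured number in this assay, with an at least 1.2-fold lower number from compound 3 to compound 4 (0.10 log units; that floor lies within the scatter). The true size of this step stays unknown because compound 3 stands only at a limit of the assay: the limit of > 50000 nM in this assay, at which 1 of the 4 values shown sits.

The compounds shown leave open how an amine or a carboxylic acid would read at this position. They also leave open how chloro compares with bromo or fluoro when the rest of the structure is the same.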